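The source may hold more compounds than are shown below. What is called first, only, known or untested is meant among the compounds shown, and "the series" means these compounds.

Measured so far: compound 1 `CCN(CC)c1nc(Cl)nc(NC(C)c2ccccc2)n1` gives 1510 nM; compound 2 `C[C@H](Nc1nc(Cl)nc(NC(C)(C)C)n1)c1ccccc1` gives 7410 nM; compound 3 `CCNc1nc(Cl)nc(NC(C)c2ccccc2)n1` gives 9770 nM, all in an ADME assay on the whole organism for inhibition, with Echinochloa crus-galli var. formosensis as the target, with a stated time of 4 days; a lower number here means a stronger inhibitor, a higher number a weaker inhibitor.

Among these three numbers compound 2 stands second highest, close to compound 3 and well apart from compound 1. Within the data shown here, the one step computed here, a 6.5-fold higher number from compound 1 to compound 3 (0.81 log units; beyond the scatter), concerns a different change and does not bear directly on the move to compound 4 `CCC(CC)Nc1nc(Cl)nc(N[C@@H](C)c2ccccc2)n1`. That move is pentan-3-yl in place of tert-butyl on a nitrogen on an aromatic ring. Among the measured compounds shown here, no measured pair shows an alkyl group exchanged for another alkyl group on that nitrogen, so nothing here points to a step beyond the scatter in either direction. The author therefore expects compound 4 to stay near compound 2, with a 1.5-fold lower number from compound 2 to compound 4 (0.17 log units; within the scatter), and estimates 5000 nM for compound 4, within 2000 nM to 15000 nM.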

Compound 4, half-maximal inhibitory concentration: 23400 nM
Beside the measured number, compound 4's estimate is 4.7-fold (0.67 log units) below it; the whole stated range lies below it.
By their numbers in this assay, from the lowest: compound 1; then compounds 2 and 3 (each within the scatter of the next); then compound 4.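

Among these compounds, replacing tert-butyl with pentan-3-yl on a nitrogen on an aromatic ring in this assay gives a 3.2-fold higher number from compound 2 to compound 4 (0.50 log units; beyond the scatter) and is the first measured exchange of one alkyl group for another at this position. This single pair shows that such an exchange can move the number beyond the scatter, here towards weaker inhibition. No measurement available here accounts for the step. Still open, going by these compounds, is how an isopropyl or cyclopentyl group on that nitrogen would compare with tert-butyl and pentan-3-yl. Also open, on these data alone, is whether a hydroxyethyl chain there would give a lower number.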